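The source may report more compounds than this note shows. Statements on the series, on what has been measured and on what is new or still open speak of the compounds shown alone.

Series notes, lipophilicity. The read-out throughout is a physicochemical assay for lipophilicity, using the shake flask method, measured as octanol-water partition, at pH 7.4; a lower number here means a more polar compound, a higher number a more lipophilic compound. Of the compounds shown here, three have numbers so far. Compound 1 `CN(C)C(=O)CN1CCC(c2cc3c(-c4ccc(=O)n(C5CCOCC5)c4)ccnc3[nH]2)CC1` gives 1.1 in this assay. Compound 2 `CC(=O)N1CCC(c2cc3c(-c4ccc(=O)n(C(C)C)c4)ccnc3[nH]2)CC1` gives 2.1. Compound 3 `COc1cc(F)ccc1-c1ccnc2[nH]c(C3CCOCC3)cc12` gives 3.9. Compound 1 thus stands lowest of the three: the nearest number is that of compound 2, which sits higher by a gap beyond the scatter, and the furthest is that of compound 3, higher again by a gap well beyond the scatter. Within the data shown here, none of these three pairs differs in a single place, so no step between measured compounds can be read off.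

Compound 4 `CCn1cc(-c2ccnc3[nH]c(C4CCN(CC(=O)N(C)C)CC4)cc23)ccc1=O` has not yet been measured in this assay. It shares the core of compound 1 and differs from it in one place: ethyl in place of oxan-4-yl on an aromatic nitrogen. Among the measured compounds shown here, no measured pair shows this exchange, so its size is not known from the data. Given that compound 1 gives 1.1 in this assay, and that the groups leaving and entering are both uncharged and small, the expected step from compound 1 to compound 4 is a number 0.10 log units lower from compound 1 to compound 4 (within the scatter), that is, no change beyond the scatter. Compound 4 is therefore expected to give about 1 in this assay, within a range from 0.5 to 1.5.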

Compound 4, distribution coefficient: 1.2
Estimate against measurement, compound 4: 0.20 log units below; the measured number falls inside the stated range.
By their numbers in this assay, from the lowest: compounds 1 and 4 (each within the scatter of the next); then compound 2; then compound 3.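

The position on the aromatic nitrogen now has its first single-place comparison: in this assay, ethyl in place of oxan-4-yl gives a number 0.10 log units higher from compound 1 to compound 4 (within the scatter), with the rest of the core of compound 1 unchanged. The exchange removes the six-membered non-aromatic ring and its hydrogen-bond acceptor, taking the group from 6 heavy atoms to 2, yet the two compounds cannot be told apart in this read-out, so at this position and on this core, a group's size and ring oxygen can differ this far without a step beyond the scatter. The series holds no information that explains this outcome.

A single pair cannot show whether the same exchange gives a comparable step when the group at the other end of the shared core is different. Also open, on these data alone, is how far the number would move with a carboxylic acid, an amine or a longer chain on this same aromatic nitrogen, groups that differ from both ethyl and oxan-4-yl in kind.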